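The compounds below may be only part of what the source reports. "The series", "measured", "known", "first", "only" and "open" are said of these compounds alone.

Measured so far:
- compound 1, `O=C(NC1CCCCC1)c1ccccc1OCc1ccccc1`: 43400 nM
- compound 2, `O=C(Nc1ccccn1)c1ccccc1OCc1ccccc1`: 11700 nM
- compound 3, `O=C(Nc1cccnc1)c1ccccc1OCc1ccccc1Cl`: 1100 nM

In an assay on lysate for inhibition of phosphatidylcholine:ceramide cholinephosphotransferase 2 (Homo sapiens), read by HPLC, with stated times of 30 min and 2 h (on this read-out higher numbers stand for weaker inhibition and lower numbers for stronger inhibition), compound 3 gives the lowest of the three numbers; compound 2 gives 11700 nM and compound 1 gives 43400 nM, both beyond the scatter away from compound 3. Within the data shown here, the only single-place step among the measured compounds is the one on the amide nitrogen, a 3.7-fold lower number from compound 1 to compound 2 (0.57 log units; beyond the scatter), and it does not touch the benzyl ring. Compound 2 and compound 3 differ in two places, so their gap cannot be assigned to either change alone.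

Compound 4, `N#Cc1ccccc1COc1ccccc1C(=O)Nc1cccnc1`, is the next compound, not yet measured in this assay. It differs from compound 3 by cyano in place of chloro on an aromatic carbon. Among the measured compounds shown here, no measured step bears on this position; nothing among the measured compounds shows what any change on the benzyl ring does to the number. The expectation therefore rests on the measured number of compound 3 alone, and the step is expected to be none beyond the scatter, a 1.4-fold higher number from compound 3 to compound 4 (0.13 log units; within the scatter), with the direction open. Compound 4 is thus estimated at 1500 nM in this assay, within a range from 400 nM to 6000 nM, that range left wide to reflect the lack of any comparable step among the measured compounds.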

Compound 4, half-maximal inhibitory concentration: 31800 nM
Compound 4: the middle estimate sits 21-fold (1.33 log units) below what was measured; the whole stated range lies below it.
By their numbers in this assay, from the lowest: compound 3; then compound 2; then compounds 4 and 1 (each within the scatter of the next).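

In this assay, among these compounds, replacing 2-chlorophenyl with 2-cyanophenyl is far from a neutral exchange: a 29-fold higher number from compound 3 to compound 4 (1.46 log units; beyond the scatter) gives the first measured step at this aromatic carbon, ortho to a large group, and it is large. Among the compounds shown here, the only step readable before, a 3.7-fold lower number from compound 1 to compound 2 (0.57 log units; beyond the scatter), lay on the amide nitrogen and was modest, so the earlier compounds gave no sign that this place on the ring could move the number so strongly. The exchange of chloro for cyano therefore matters a great deal within this pair, but nothing measured here bears on why these two groups differ so sharply.

On these data alone, it remains open how the core of compound 3 behaves with a plain hydrogen on this carbon, which would show whether chloro lowers the number, cyano raises it, or both occur. Also open, as far as these compounds go, is where fluoro, bromo, methyl or methoxy at this place would fall relative to chloro and cyano, and whether any of them could match or improve on compound 3.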